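Methylindazolyl in place of dimethylaminophenyl on a shared core

The source may hold more compounds than are shown below. What is called first, only, known or untested is meant among the compounds shown, and "the series" means these compounds.

Of the compounds shown here, three on a shared core have been measured in a functional assay on MCF7 cells (Homo sapiens) for inhibition, read by CCK-8 assay, with a stated time of 48 h; a lower number here means a stronger inhibitor, a higher number a weaker inhibitor. Compound 1 `COc1cc(-c2ccnc3cc(-c4ccc5cc[nH]c5c4)nn23)cc(OC)c1OC` gives 23 nM. Compound 2 `COc1cc(-c2ccnc3cc(-c4c[nH]c5ccccc45)nn23)cc(OC)c1OC` gives 85 nM in this assay, and compound 3 `COc1cc(-c2ccnc3cc(-c4ccc(N(C)C)cc4)nn23)cc(OC)c1OC` gives 44 nM. Compound 3 stands second highest of the three numbers, nearest to compound 1 and furthest from compound 2, and both of those gaps lie within the scatter: a 1.9-fold higher number from compound 1 to compound 3 (0.28 log units; within the scatter) and a 1.9-fold lower number from compound 2 to compound 3 (0.29 log units; within the scatter). Among the measured compounds shown here, the one step beyond the scatter is a 3.7-fold higher number from compound 1 to compound 2 (0.57 log units; beyond the scatter).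

Compound 4 `COc1cc(-c2ccnc3cc(-c4ccc5cnn(C)c5c4)nn23)cc(OC)c1OC` is not yet measured. Its change from compound 3 is 1-methyl-1H-indazol-6-yl in place of 4-(dimethylamino)phenyl on an aromatic carbon. For the measured compounds named here, no measured step covers this exact exchange. The closest guidance comes from compound 1, whose 1H-indol-6-yl group also joins a five-membered ring to a six-membered one and which sits close to compound 3 in a 1.9-fold higher number from compound 1 to compound 3 (0.28 log units; within the scatter). On that basis the step is expected to be small, about a 1.5-fold lower number from compound 3 to compound 4 (0.17 log units; within the scatter). Compound 4 is estimated at 30 nM, within a range from 12 nM to 80 nM.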

Compound 4, half-maximal inhibitory concentration: 279 nM
Compound 4: the middle estimate sits 9.3-fold (0.97 log units) below what was measured; measured number above the stated range.
By their numbers in this assay, from the lowest: compounds 1, 3 and 2 (each within the scatter of the next, the first and the last beyond it); then compound 4.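

The earlier groups at this position lay no further apart than a 3.7-fold higher number from compound 1 to compound 2 (0.57 log units; beyond the scatter) and 1-methyl-1H-indazol-6-yl falls outside that span, with a 6.3-fold higher number from compound 3 to compound 4 (0.80 log units; beyond the scatter) and a 3.3-fold higher number from compound 2 to compound 4 (0.52 log units; beyond the scatter) and, as the widest gap in the set, a 12-fold higher number from compound 1 to compound 4 (1.08 log units; beyond the scatter). A five-membered aromatic ring joined to a six-membered one therefore does not by itself keep the number low here, since 1H-indol-6-yl and 1-methyl-1H-indazol-6-yl both have that form and yet stand furthest apart. No evidence is available on what lies behind this loss of potency.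

The compounds shown do not separate the extra ring nitrogen from the methyl on the ring nitrogen, as neither 1H-indazol-6-yl nor 1-methyl-1H-indol-6-yl is among them. They also leave open how a single-ring group with a smaller substituent, such as 4-aminophenyl or 4-methoxyphenyl, would compare with 4-(dimethylamino)phenyl.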